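The compounds below may be only part of what the source reports. "The series", "measured", "known", "first", "only" and "open" are said of these compounds alone.

Compound 1 `CCc1ccc(-c2nc3c(c(C)nn3-c3ccccc3)c(-c3ccccc3Br)c2C#N)cc1`: > 20000 nM
Compound 2 `CCc1ccc(-c2nc3c(c(C)nn3-c3ccccc3)c(-c3ccccc3C(=O)O)c2C#N)cc1`: > 20000 nM

The measured compounds were tested in an ADME assay on BJ cells (Homo sapiens) for cytotoxicity, with a stated time of 72 h; a lower number here means that less compound is needed, a higher number that more compound is needed for the effect. There, compound 2 gives > 20000 nM, which is a limit and not a number. Compound 1 also gives only a limit, > 20000 nM. Compound 3 `CCc1ccc(-c2nc3c(c(C)nn3-c3ccccc3)c(-c3ccccc3OC(F)(F)F)c2C#N)cc1` has trifluoromethoxy in place of carboxy on an aromatic carbon, ortho to a large group: trifluoromethoxy in place of carboxy on an aromatic carbon.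

For the measured compounds named here, the one measured step that bears on this change is a step that the two limits leave unreadable from compound 1 to compound 2, and its size cannot be read. The evidence therefore amounts to the limit of > 20000 nM in this assay, at which 2 of the 2 values shown sit. Trifluoromethoxy itself has not been measured on this core, so no step beyond the usual scatter is expected in this assay, in either direction. The expected size is a number no higher from compound 2 to compound 3 (the limit leaves the size open). Compound 3 is estimated at 20000 nM, with an expected range of 8000 nM to 30000 nM, and it may well report only a limit.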

Compound 3, half-maximal effective concentration: > 20000 nM
Compound 3: a limit, no number; the forecaster's own chance of this, stated with the estimate: 80%; the middle value sits exactly at the limit.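

For the compounds shown here, compound 1, compound 2 and compound 3 each give only a limit in this assay, not a number, so no step among them can be read. The compounds shown leave open how much of each is needed for the effect, and whether bromo, carboxy and trifluoromethoxy differ at all here.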